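The compounds below may be only part of what the source reports. "The series", "measured", "known", "first", "only" and "open" are said of these compounds alone.

Three amides sharing one core were compared in an assay on isolated protein for binding affinity to melanin-concentrating hormone receptor 1 (Homo sapiens); on this read-out higher numbers stand for weaker inhibition and lower numbers for stronger inhibition. Compound 1 `COc1cccc(C(=O)NC2CCN(Cc3ccc4ccccc4c3)CC2)c1` gives 29 nM. Compound 2 `O=C(NC1CCN(Cc2ccc3ccccc3c2)CC1)c1ccc(F)cc1` gives 36 nM. Compound 3 `O=C(NC1CCN(Cc2ccc3ccccc3c2)CC1)c1cc(F)cc(F)c1` gives 65 nM, the highest of the three numbers: the step of a 2.2-fold higher number from compound 1 to compound 3 (0.35 log units; beyond the scatter) lies beyond the scatter, whereas the step of a 1.8-fold higher number from compound 2 to compound 3 (0.26 log units; within the scatter) stays within it.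

Compound 4 `O=C(NC1CCN(Cc2ccc3ccccc3c2)CC1)c1ccc(Cl)cc1` differs from compound 3 in one place: 4-chlorophenyl in place of 3,5-difluorophenyl on a carbonyl carbon. Going by the values given here, two measured steps bear on this change. The step of a 1.8-fold higher number from compound 2 to compound 3 (0.26 log units; within the scatter) shows that exchanging one ring pattern of halogens for the other moved the number only within the scatter, and the step of a 1.2-fold higher number from compound 1 to compound 2 (0.09 log units; within the scatter) was also within the scatter. Nothing measured here separates chlorine from fluorine on the ring, so the expected change is small and, if anything, back toward the level of compound 2. The step from compound 3 to compound 4 is therefore estimated at a 1.7-fold lower number from compound 3 to compound 4 (0.23 log units; within the scatter). Compound 4 is expected to give 38 nM, with a range of 15 nM to 90 nM.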

Compound 4, inhibition constant: 232 nM
Compound 4: middle estimate off by 6.1-fold (0.79 log units), on the low side; measured number outside the range, above it.
By their numbers in this assay, from the lowest: compounds 1, 2 and 3 (each within the scatter of the next, the first and the last beyond it); then compound 4.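

Until now, the groups on the carbonyl carbon had spanned only a narrow range, but this position proves less forgiving than those compounds suggested, since chloro in place of fluoro on an aromatic carbon gives the largest change yet from such a small exchange in this assay (a 6.4-fold higher number from compound 2 to compound 4 (0.81 log units; beyond the scatter)). Fluoro and chloro are therefore not interchangeable here, and 4-chlorophenyl also falls behind both 3,5-difluorophenyl (a 3.6-fold higher number from compound 3 to compound 4 (0.55 log units; beyond the scatter)) and 3-methoxyphenyl (an 8.0-fold higher number from compound 1 to compound 4 (0.90 log units; beyond the scatter)), making compound 4 the one clear outlier of the four. Nothing presented here accounts for this loss.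

The compounds shown leave open whether bromo, methyl or trifluoromethyl in place of the chloro would raise the number further or restore the level of compound 2. They also leave open whether the same penalty from chloro would appear on a ring carrying an amine or a carboxylic acid.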